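Bromo for fluoro on a furan-bearing amidoxime scaffold

The source may hold more compounds than are shown below. What is called first, only, known or untested is meant among the compounds shown, and "the series" means these compounds.

Measured so far:
compound 1 `O/N=C(/Nc1cccc(Br)c1)c1ccc2occc2c1` gives 440 nM
compound 2 `OCc1cc2cc(/C(=N\O)Nc3cccc(Br)c3)ccc2o1` gives 710 nM
compound 3 `COCc1cc2cc(/C(=N\O)Nc3cccc(F)c3)ccc2o1` gives 7100 nM

In an assay on isolated protein for inhibition of Indoleamine 2,3-dioxygenase 1 (Homo sapiens), read by spectrophotometry (on this read-out lower numbers stand for stronger inhibition and higher numbers for weaker inhibition), compound 3 stands at the highest of the three numbers: compound 2 lies one step down in the series, and compound 1 lies furthest from it. Compound 4 `COCc1cc2cc(/C(=N\O)Nc3cccc(Br)c3)ccc2o1` is the next member and differs from compound 3 by bromo in place of fluoro on an aromatic carbon.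

Among the measured compounds shown here, no measured step in this set changes the halogen alone. For the measured compounds named here, the only single-point step, a 1.6-fold higher number from compound 1 to compound 2 (0.21 log units; within the scatter), concerns the hydroxymethyl group and lies within the scatter, so it says nothing about the halogen. Compound 2 and compound 3 differ in two places at once, and their values show a wide gap, but how much of it belongs to each change cannot be separated. What can be said is that both compounds carrying bromo, compound 1 and compound 2, sit far below compound 3 on this assay.

On that basis compound 4 is expected to fall between compound 3 and the bromo-bearing pair, with a drop of about a 4.7-fold lower number from compound 3 to compound 4 (0.68 log units; beyond the scatter). The estimate for compound 4 is 1500 nM, with a range from 500 nM to 4500 nM.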

Compound 4, half-maximal inhibitory concentration: 930 nM
For compound 4 the middle estimate is 1.6-fold (0.21 log units) above the measured one, and the stated range covers the measured number.
By their numbers in this assay, from the lowest: compounds 1, 2 and 4 (each within the scatter of the next, the first and the last beyond it); then compound 3.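

In this assay, among the compounds shown here, the step of a 7.6-fold lower number from compound 3 to compound 4 (0.88 log units; beyond the scatter) is the first reading of the halogen on its own: with the rest of the molecule fixed, 3-bromophenyl in place of 3-fluorophenyl accounts for a change beyond the scatter, so this position meta to a large group responds to the identity of the halogen. With bromo held constant, the other two comparisons are both smaller: a 1.3-fold higher number from compound 2 to compound 4 (0.12 log units; within the scatter) shows that methylating the hydroxymethyl oxygen leaves the reading within the scatter, and a 2.1-fold higher number from compound 1 to compound 4 (0.33 log units; beyond the scatter) shows that adding methoxymethyl to the core of compound 1 has only a modest effect, just beyond the scatter. Nothing available gives a cause for the difference between the two halogens.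

The compounds shown leave open whether the same exchange of fluoro for bromo would read alike on the core of compound 1 or alongside the hydroxymethyl group of compound 2, and where chloro, iodo or trifluoromethyl would fall at this position. They also leave open how an amine or a longer ether chain would read in place of methoxymethyl.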